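A few compounds are considered here, and "the series" means these few. Any claim that something is new, unique, unknown or untested is made for them only; others in the source may bear on it.

Working notes on a small series sharing one core. Among the measured compounds shown here, in an ADME assay (liver) for metabolic stability, with Liver microsome (Homo sapiens) as the target, read by LC-MS, using microsomes, with a stated time of 1 h, tested at 5 uM (a lower number here means that less of the compound is left, a higher number that more of the compound is left), compound 2 (`Cc1nc(-c2cccc(F)c2)c(C(=O)N2CCN(c3cc(Cl)cc(Cl)c3)CC2)o1`) gives 75.9%, the higher of the two numbers so far. Compound 1 (`COc1cc(OC)cc(N2CCN(C(=O)c3oc(C)nc3-c3ccccc3F)CC2)c1`) gives 15%, a gap beyond the scatter.

Compound 3 (`COc1cc(OC)cc(N2CCN(C(=O)c3oc(C)nc3-c3cccc(F)c3)CC2)c1`) is not yet measured. It departs from compound 2 by 3,5-dimethoxyphenyl in place of 3,5-dichlorophenyl on an amine nitrogen in a ring, with 3,5-dimethoxyphenyl in place of 3,5-dichlorophenyl on an amine nitrogen in a ring.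

For the measured compounds named here, no measured pair differs in one place only, so this change has no direct precedent. Going by the values given here, the only guide is compound 1, which also carries the 3,5-dimethoxyphenyl group and gives 15%. That single comparison is thin support, but a fall beyond the scatter is expected in this assay. The expected step is a number 55.9 percentage points lower from compound 2 to compound 3 (beyond the scatter). For compound 3 the estimate is 20%, with an expected range of 7% to 42%.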

Compound 3, percent of the compound remaining: 11.3%
Estimate against measurement, compound 3: 8.7 percentage points above; low and high end bracket the measured number.
By their numbers in this assay, from the lowest: compounds 3 and 1 (each within the scatter of the next); then compound 2.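

In this assay, the exchange of 3,5-dichlorophenyl for 3,5-dimethoxyphenyl on an amine nitrogen in a ring now stands as a change in one place, and the step is a number 64.6 percentage points lower from compound 2 to compound 3 (beyond the scatter). The other single change, 3-fluorophenyl in place of 2-fluorophenyl on an aromatic carbon, gives a number 3.7 percentage points lower from compound 1 to compound 3 (within the scatter), so with 3,5-dimethoxyphenyl on the amine nitrogen the two fluorophenyl forms are not told apart in this assay. Nothing at hand explains the large step at the amine nitrogen.

From the compounds shown here alone, whether the fluorophenyl change is equally small with 3,5-dichlorophenyl on the amine nitrogen remains open. So does the place of other groups at that position, such as 3,5-dimethylphenyl or 3,5-difluorophenyl, on the range between the two groups compared here.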